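The source may hold more compounds than are shown below. What is called first, only, known or untested is meant among the compounds shown, and "the series" means these compounds.

Three compounds of this series have been examined in a functional assay on artery with platelet-activating factor receptor (Rattus norvegicus) as the target; on this read-out lower numbers stand for an effect already at smaller amounts and higher numbers for an effect only at larger amounts of compound. Compound 1, with the structure `CCCCCCCCCCCCCCCCCC1OCC(COCCCCCC[n+]2ccccc2)O1`, reached only the limit of the assay, giving > 5 mg/kg. Compound 2, with the structure `CCCCCCCCCCCCCCC1COC(COCCCC[n+]2ccsc2)C1`, also stopped at the limit, giving > 5 mg/kg. Compound 3, with the structure `CCCCCCCCCCCCCCC1COC(COCCCCCC[N+](C)(C)C)C1`, likewise stopped at the limit, giving > 5 mg/kg. Going by the values given here, the one measured step, a step that the two limits leave unreadable from compound 2 to compound 3, stays unreadable because the limit of > 5 mg/kg in this assay, at which 3 of the 3 values shown sit, sits at both of its ends, so nothing about the size or direction of that change can be taken from it.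

Compound 4, with the structure `CCCCCCCCCCCCCCC1COC(COCCCCCCC[n+]2ccsc2)C1`, has not yet been measured. It differs from compound 3 by a group of 6 heavy atoms (4 carbon, 1 nitrogen, 1 sulfur; one five-membered aromatic ring with 2 hetero atoms) in place of a group of 4 heavy atoms (3 carbon, 1 nitrogen; no ring), on a saturated chain carbon, six bonds along the chain from an oxygen on a saturated carbon. Among the compounds with values here, no measured step matches this change in a readable way, and every value so far rests at the same limit, so no direction can be drawn from the data. The step that the limit leaves unreadable from compound 3 to compound 4 is therefore expected to be small and without a readable direction. Compound 4 is estimated at 8 mg/kg, within 3 mg/kg to 30 mg/kg, and it is expected that this assay again reports only a limit.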

Compound 4, dose for 50% inhibition: 1.5 mg/kg
Compound 4: middle estimate off by 5.3-fold (0.73 log units), on the high side; the measured number lies below the stated range.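

In this assay, the place six bonds along the chain from an oxygen on a saturated carbon now gives a readable answer, since compound 4 is the only compound shown with a value that is not a limit: the limit of > 5 mg/kg in this assay, at which 3 of the 4 values shown sit.

Keeping the five-membered aromatic ring and lengthening the chain that carries it gives an at least 3.3-fold lower number from compound 2 to compound 4 (0.52 log units; beyond the scatter), so the presence of this ring alone does not settle the result. Putting the group with this ring in place of the ring-free group of 4 heavy atoms gives an at least 3.3-fold lower number from compound 3 to compound 4 (0.52 log units; beyond the scatter), and since net charge is +1 on both sides, this change is not one of net charge.

From the compounds shown here alone, the step from compound 2 to compound 3 cannot be read, so the part played by the ring at a given chain length stays unknown. Going by these compounds, whether a longer chain carrying the same ring would lower the number further, or an amine at its end would retain the effect, remains open.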